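This account rests on a few compounds, and the source may have more. Where it says the series, first, only, none or still open, it means among the compounds named here.

Compound 1 `FC(F)(F)c1ccc2cc(-c3nn[nH]n3)cnc2c1` reports only a limit of the assay in a functional assay on the whole organism (strain Sprague-Dawley) for inhibition, with Rattus norvegicus as the target (on this read-out lower numbers stand for an effect already at smaller amounts and higher numbers for an effect only at larger amounts of compound), < 10 mg/kg. Compound 2 `c1ccc2ncc(-c3nn[nH]n3)cc2c1` gives 10 mg/kg in this assay. Compound 3 `c1nc2ccc(C3CCCCC3)cc2cc1-c1nn[nH]n1` gives 5 mg/kg in this assay.

Compound 2 stands at the highest of the two numbers; its nearest neighbour is compound 3, with a 2.0-fold lower number from compound 2 to compound 3 (0.30 log units; within the scatter), which lies within the scatter, so the two cannot be ordered. Compound 1 sits at the limit of < 10 mg/kg in this assay, at which 1 of the 3 values shown sits, and the step of a number no lower from compound 1 to compound 2 (the limit leaves the size open) cannot be sized. Compound 4 `Cc1cccc2cc(-c3nn[nH]n3)cnc12` differs from compound 2 by methyl in place of hydrogen on an aromatic carbon. Going by the values given here, the only measurable step that bears on such a change, a 2.0-fold lower number from compound 2 to compound 3 (0.30 log units; within the scatter), stayed within the scatter, so no movement beyond the scatter is expected in this assay. Compound 4 is therefore estimated at 10 mg/kg, between 5 mg/kg and 20 mg/kg, an expected step of no change at the digits printed from compound 2 to compound 4 (within the scatter).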

Compound 4, minimum effective dose: < 25 mg/kg
Compound 4 gave a limit, no number; the forecaster's own chance of this, stated with the estimate: 25%; the middle value does not contradict the limit.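

Going by these compounds alone, compound 4 gives only a limit of the assay, < 25 mg/kg, so no step from compound 2 to compound 4 can be read. The compounds shown leave open whether methyl in place of hydrogen changes the minimum effective dose at all, and in which direction.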